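This account rests on a few compounds, and the source may have more. Where it says the series, first, only, none or still open, it means among the compounds named here.

Compound 2 `O=C(Nc1ccc(Cl)cc1CN1C(=O)c2ccccc2C1=O)c1ccccc1` carries a benzoyl group on the amide nitrogen of the shared core. In an assay on CHO cells for positive allosteric modulation of metabotropic glutamate receptor 5 (Rattus norvegicus), read by FLIPR (a higher number here means that more compound is needed for the effect, a lower number that less compound is needed), compound 2 gives < 1000 nM, which is a limit of the assay and not a number. Compound 1 `O=C(Nc1ccc(Cl)cc1CN1C(=O)c2ccccc2C1=O)c1cccnc1`, in this assay gives < 1000 nM, likewise a limit. The step that the two limits leave unreadable from compound 1 to compound 2 cannot be sized because of the limit of < 1000 nM in this assay, at which 2 of the 2 values shown sit. Compound 3 `O=C(Nc1ccc(Cl)cc1CN1C(=O)c2ccccc2C1=O)c1ccco1` differs from compound 2 by furan-2-yl in place of phenyl on a carbonyl carbon. Within the data shown here, the only measured step touches the same carbonyl carbon but gives no readable size, so the expected step that the limit leaves unreadable from compound 2 to compound 3 rests on little. Compound 3 is estimated at 400 nM, expected between 60 nM and 1500 nM.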

Compound 3, half-maximal effective concentration: < 1000 nM
Compound 3: only a limit was reported; the forecaster's own chance of this, stated with the estimate: 60%; the middle value does not contradict the limit.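

Among these compounds, no step can be sized among compound 1, compound 2 and compound 3, because each gives only a limit of the assay and not a number: (the limit of < 1000 nM in this assay, at which 3 of the 3 values shown sit). On these data alone, how far pyridin-3-yl, phenyl and furan-2-yl on the carbonyl carbon truly differ in this assay stays open.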